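Bcl-2 series: exchanging the amine substituent on compound 3

The source may hold more compounds than are shown below. What is called first, only, known or untested is meant among the compounds shown, and "the series" means these compounds.

Compound 3 `CC1(C)CCC(CN2CCN(c3ccc(C(=O)NS(=O)(=O)c4ccc(NC5CCOC5)c([N+](=O)[O-])c4)c(Oc4cnc5[nH]ccc5c4)c3)CC2)=C(c2ccc(C(F)(F)F)cc2)C1` gives 1.9 nM in an assay on isolated protein for displacement of a labelled ligand from Apoptosis regulator Bcl-2 (Homo sapiens), with a stated time of 15 min (a lower number here means a stronger inhibitor, a higher number a weaker inhibitor), the highest of the three numbers shown. Compound 2 `CC1(C)CCC(CN2CCN(c3ccc(C(=O)NS(=O)(=O)c4ccc(NCC5CCOCC5)c([N+](=O)[O-])c4)c(Oc4cnc5[nH]ccc5c4)c3)CC2)=C(c2ccccc2C(F)(F)F)C1` gives 1.7 nM, within the scatter of compound 3, while compound 1 `CC1(C)CCC(CN2CCN(c3ccc(C(=O)NS(=O)(=O)c4ccc(NCC5CCOCC5)c([N+](=O)[O-])c4)c(Oc4cnc5[nH]ccc5c4)c3)CC2)=C(c2ccc(Cl)cc2C(F)(F)F)C1` gives 0.86 nM, beyond the scatter from compound 3. Going by the values given here, the only single-point step measured, a 2.0-fold higher number from compound 1 to compound 2 (0.30 log units; within the scatter), concerns hydrogen in place of chloro and not the site altered here. Compound 4 `CCN1CCC(COc2ccc(S(=O)(=O)NC(=O)c3ccc(N4CCN(CC5=C(c6ccc(C(F)(F)F)cc6)CC(C)(C)CC5)CC4)cc3Oc3cnc4[nH]ccc4c3)cc2[N+](=O)[O-])CC1` differs from compound 3 by (1-ethylpiperidin-4-yl)methoxy in place of (oxolan-3-yl)amino on an aromatic carbon. Among the compounds with values here, no measured step bears on this exchange, so no step beyond the scatter is expected; a 1.1-fold higher number from compound 3 to compound 4 (0.02 log units; within the scatter) is the estimated outcome, with a widened range for the untested change. Compound 4 is therefore expected at 2 nM, between 0.6 nM and 6.5 nM.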

Compound 4, half-maximal inhibitory concentration: 0.5 nM
Estimate against measurement, compound 4: 4.0-fold (0.60 log units) above; the whole stated range lies above it.
By their numbers in this assay, from the lowest: compounds 4, 1, 2 and 3 (each within the scatter of the next, the first and the last beyond it).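

In this assay, this position, ortho to a nitro group, accepts a larger substituent with its hydrogen-bond donor gone: (1-ethylpiperidin-4-yl)methoxy in place of (oxolan-3-yl)amino gives a 3.8-fold lower number from compound 3 to compound 4 (0.58 log units; beyond the scatter). The exchange changes the linking atom, the ring and the heavy-atom count together, so the step cannot be assigned to any one of them. Nothing at hand accounts for the step.

Open, as far as these compounds go, is which part carries it: a (1-ethylpiperidin-4-yl)methylamino group would keep the ring and restore the amine link, while an (oxan-4-yl)methoxy group would keep the ether link and replace the ring nitrogen with oxygen.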